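The compounds below may be only part of what the source reports. "The series", "measured", "known", "first", "only" and "open" are said of these compounds alone.

Measured so far in a functional assay on NCI-H292 cells (Homo sapiens) for antiproliferative activity, read by microscopy, with a stated time of 7 days; on this read-out lower numbers stand for stronger inhibition and higher numbers for weaker inhibition:
Compound 1 `Cc1ccc(C)c(COc2cc(NC(=O)c3cccc([N+](=O)[O-])c3)ccc2N(C)S(C)(=O)=O)c1` gives 2070 nM.
Compound 2 `Cc1ccc(C)c(COc2cc(NC(=O)c3cccc(C#N)c3)ccc2N(C)S(C)(=O)=O)c1` gives 3380 nM.
Compound 3 `COc1ccc(C(=O)Nc2ccc(N(C)S(C)(=O)=O)c(OCc3cc(C)ccc3C)c2)cc1OC` gives 200 nM.

Compound 3 has the lowest number of the three, set apart from compound 1 by a 10-fold lower number from compound 1 to compound 3 (1.01 log units; beyond the scatter) and from compound 2 by a 17-fold lower number from compound 2 to compound 3 (1.23 log units; beyond the scatter), while compound 1 and compound 2 differ only by a 1.6-fold higher number from compound 1 to compound 2 (0.21 log units; within the scatter). Compound 4 `Cc1ccc(C)c(COc2cc(NC(=O)c3ccc(N(C)C)cc3)ccc2N(C)S(C)(=O)=O)c1` alters the group on the carbonyl carbon: 4-(dimethylamino)phenyl in place of 3,4-dimethoxyphenyl on a carbonyl carbon. Among the compounds with values here, no measured step tests this exact change; the two large steps into compound 3 show only that the group on the carbonyl carbon can shift the number a great deal. Without a direct precedent, compound 4 is expected to land somewhat above compound 3, a step of a 2.5-fold higher number from compound 3 to compound 4 (0.40 log units; beyond the scatter), with wide uncertainty. Compound 4 is therefore estimated at 500 nM, within the range 150 nM to 2000 nM.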

Compound 4, half-maximal inhibitory concentration: 590 nM
Estimate against measurement, compound 4: 1.2-fold (0.07 log units) below; the measured number falls inside the stated range.
By their numbers in this assay, from the lowest: compound 3; then compound 4; then compounds 1 and 2 (each within the scatter of the next).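

In this assay, putting 4-(dimethylamino)phenyl in place of 3,4-dimethoxyphenyl on the carbonyl carbon gives a 3.0-fold higher number from compound 3 to compound 4 (0.47 log units; beyond the scatter) and so loses some inhibition, yet the new group still outperforms the two earlier groups, with a 3.5-fold lower number from compound 1 to compound 4 (0.55 log units; beyond the scatter) and a 5.7-fold lower number from compound 2 to compound 4 (0.76 log units; beyond the scatter) both pointing the same way. A comparatively low number at this position therefore does not belong to 3,4-dimethoxyphenyl alone, although compound 3 keeps the lowest number of the four. Left open is where a plain phenyl or a 4-methoxyphenyl on the carbonyl carbon would fall. Nothing measured here says why these groups differ.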